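The source may hold more compounds than are shown below. What is called first, only, known or untested is meant among the compounds shown, and "the series" means these compounds.

Compound 1, `O=S(=O)(c1ccc(F)cc1)c1cnc2cc(F)ccc2c1-c1cccc(F)c1`, has been tested in an ADME assay on microsomes from liver (Homo sapiens) for metabolic stability, tested at 2.5 uM (on this read-out higher numbers stand for fast clearance and lower numbers for slow clearance), where compound 1 gives 0.95 mL/min. Among the measured compounds shown here, only one other compound has a number so far: compound 2, `O=S(=O)(c1cc(F)cc(F)c1)c1cnc2c(F)cccc2c1-c1cccc(Cl)c1`, gives 0.64 mL/min in this assay, and the gap between the two lies within the usual scatter, so neither can be said to clear faster than the other. Compound 3, `O=S(=O)(c1cc(F)cc(F)c1)c1cnc2cc(F)ccc2c1-c1cccc(F)c1`, differs from compound 1 in one place: 3,5-difluorophenyl in place of 4-fluorophenyl on a sulfonyl sulfur. For the measured compounds named here, no step between two measured compounds shows what this change does on its own, so no shift beyond the scatter is expected. The step of a 1.2-fold lower number from compound 1 to compound 3 (0.07 log units; within the scatter) is therefore estimated to be small. Compound 3 is expected to give about 0.8 mL/min, between 0.4 mL/min and 1.6 mL/min.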

Compound 3, intrinsic clearance in a liver preparation (reported as CLH), per the amount of preparation that the assay uses: 0.06 mL/min
Compound 3: the middle estimate sits 13-fold (1.12 log units) above what was measured; measured number below the stated range.
By their numbers in this assay, from the lowest: compound 3; then compounds 2 and 1 (each within the scatter of the next).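

On the sulfonyl sulfur, putting 3,5-difluorophenyl in place of 4-fluorophenyl gives a 16-fold lower number from compound 1 to compound 3 (1.20 log units; beyond the scatter) in this assay. Among the compounds shown here, this is the first sign that this position matters: a single change here, with the rest of the molecule the same, moves clearance well beyond the scatter. The data at hand offer no explanation for the size of this step.

On these data alone, it remains open whether both fluorines are needed, as 3-fluorophenyl on this sulfur would show. Also open, as far as these compounds go, is how a pyridine ring or a plain methyl group would behave there.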